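From Fluoro to Bromo in a Tight Series

The source may hold more compounds than are shown below. What is called first, only, known or untested is meant among the compounds shown, and "the series" means these compounds.

In a functional assay on HL-60 cells (Homo sapiens) for cytotoxicity, read by luminescence and CellTiter-Glo, with a stated time of 3 days (a higher number here means a weaker inhibitor, a lower number a stronger inhibitor), compound 1 `O=C(Nc1cc(C(F)(F)F)cc(C(F)(F)F)c1)c1cc(Br)c(-c2ccccc2)cc1O` gives 430 nM, compound 2 `O=C(Nc1cc(C(F)(F)F)cc(C(F)(F)F)c1)c1cc(Br)c(F)cc1O` gives 250 nM and compound 3 `O=C(Nc1cc(C(F)(F)F)cc(C(F)(F)F)c1)c1cc(F)ccc1O` gives 320 nM, which lies within the scatter of the other two values. Compound 4 `O=C(Nc1cc(C(F)(F)F)cc(C(F)(F)F)c1)c1cc(Br)ccc1O` has bromo in place of fluoro on an aromatic carbon, para to a hydroxy group: bromo in place of fluoro on an aromatic carbon. Among the measured compounds shown here, the only measured single change is a different swap, fluoro in place of phenyl, and a 1.7-fold lower number from compound 1 to compound 2 (0.24 log units; within the scatter) stays small. Compound 1 and compound 2 already carry bromo in that place, and their values lie within the scatter of compound 3. No step beyond the scatter is expected in this assay, and the estimated change is a 1.1-fold lower number from compound 3 to compound 4 (0.06 log units; within the scatter). For compound 4 the expected value is 280 nM, with an estimated range of 130 nM to 600 nM.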

Compound 4, half-maximal inhibitory concentration: 290 nM
The estimate for compound 4 lay 1.0-fold (0.02 log units) below the measured number, and the stated range covers the measured number.
By their numbers in this assay, from the lowest: compounds 2, 4, 3 and 1 (each within the scatter of the next).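

Bromo in place of fluoro on the aromatic carbon para to a hydroxy group gives a 1.1-fold lower number from compound 3 to compound 4 (0.04 log units; within the scatter) and so leaves the number unmoved beyond the scatter. Two further single changes on an aromatic carbon also stay within it: hydrogen in place of fluoro gives a 1.2-fold higher number from compound 2 to compound 4 (0.06 log units; within the scatter) and hydrogen in place of phenyl gives a 1.5-fold lower number from compound 1 to compound 4 (0.17 log units; within the scatter) in this small set. Nothing available offers an explanation for this flatness.

On these data alone, whether an amine or a carboxylic acid at the same position would shift the number beyond the scatter remains open. So does the outcome with a longer chain there.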